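From 4-methylphenyl to 2-methylphenyl on the shared core

A few compounds are considered here, and "the series" means these few. Any claim that something is new, unique, unknown or untested is made for them only; others in the source may bear on it.

Among the compounds with values here, only two compounds have been measured in a functional assay on HCT-15 cells (Homo sapiens) for cytotoxicity; on this read-out higher numbers stand for weaker inhibition and lower numbers for stronger inhibition. Compound 1 `Cc1ccc2c(N3CCN(C)CC3)nc(-c3ccc(Cl)cc3)cc2c1` gives 6030 nM. Compound 2 `Cc1ccc(-c2cc3cc(C)ccc3c(N3CCN(C)CC3)n2)cc1` gives 8320 nM, which places it within the scatter of compound 1. Compound 3 `Cc1ccc2c(N3CCN(C)CC3)nc(-c3ccccc3C)cc2c1` keeps the shared core, and its structural change is 2-methylphenyl in place of 4-methylphenyl on an aromatic carbon, next to the ring nitrogen. Within the data shown here, the one measured step that bears on this is a 1.4-fold higher number from compound 1 to compound 2 (0.14 log units; within the scatter), with methyl in place of chloro on an aromatic carbon. That step swaps one group for another, so it bears on the new change only indirectly. Among the measured compounds shown here, no measured pair tests the move from 4-methylphenyl to 2-methylphenyl. No step beyond the scatter is therefore expected in this assay, and no direction is favoured. The expected step is a 1.1-fold lower number from compound 2 to compound 3 (0.05 log units; within the scatter). Compound 3 is estimated at 7500 nM, with an expected range of 3000 nM to 19000 nM.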

Compound 3, half-maximal inhibitory concentration: 77600 nM
Estimate against measurement, compound 3: 10-fold (1.01 log units) below; the whole stated range lies below it.
By their numbers in this assay, from the lowest: compounds 1 and 2 (each within the scatter of the next); then compound 3.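

In this assay, the aromatic carbon next to the ring nitrogen proves sensitive to where the methyl sits on its aryl group: 2-methylphenyl in place of 4-methylphenyl gives a 9.3-fold higher number from compound 2 to compound 3 (0.97 log units; beyond the scatter), although the two groups have the same atoms. Replacing 4-chlorophenyl with 2-methylphenyl gives a similar result, a 13-fold higher number from compound 1 to compound 3 (1.11 log units; beyond the scatter), whereas the exchange between the two 4-substituted groups stayed within the scatter, so among these three compounds only the 2-methylphenyl group stands apart. Nothing available explains this weakening.

As far as these compounds go, it remains open whether the loss is specific to methyl or would also appear with 2-chlorophenyl or 2-methoxyphenyl. Where 3-methylphenyl or unsubstituted phenyl would fall relative to these compounds is also unresolved.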